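Compound 4: an untested swap on the shared core

The source may hold more compounds than are shown below. What is called first, only, known or untested is meant among the compounds shown, and "the series" means these compounds.

Among the measured compounds shown here, four compounds share one core, and only one has a reading so far. In an ADME assay on NIH3T3 cells (Mus musculus) for cytotoxicity, with a stated time of 72 h (a higher number here means a weaker inhibitor, a lower number a stronger inhibitor), compound 1 (`COc1cccc(CNc2ncnc3c2ncn3[C@@H]2O[C@H](CO)[C@@H](O)[C@H]2O)c1`) gives a limit of the assay (> 166000 nM) and not a number. Compound 2 (`OC[C@H]1O[C@@H](n2cnc3c(NCc4ccc(Cl)c(Cl)c4)ncnc32)[C@H](O)[C@@H]1O`) has no result ("not determined" (no result reported)) in this assay to compare with. Compound 3 (`COc1ccc(CNc2ncnc3c2ncn3[C@@H]2O[C@H](CO)[C@@H](O)[C@H]2O)c(OC)c1`) likewise has no result ("not determined" (no result reported)) and so stands nowhere on the scale.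

Compound 4 (`OC[C@H]1O[C@@H](n2cnc3c(NCc4ccc(F)c(Cl)c4)ncnc32)[C@H](O)[C@@H]1O`) differs from compound 3 in one place, with 3-chloro-4-fluorophenyl in place of 2,4-dimethoxyphenyl on a saturated chain carbon bound to a nitrogen on an aromatic ring. For the measured compounds named here, no measured pair shows what such a swap does. Going by the values given here, the only measured guide is the limit of compound 1 (> 166000 nM). A modest move toward lower numbers in this assay is therefore expected, and it may be no larger than the usual scatter. Compound 4 is estimated at 90000 nM (expected range 20000 nM to 170000 nM).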

Compound 4, half-maximal inhibitory concentration: > 166000 nM
Compound 4: only a limit was reported (the forecaster's own chance of this, stated with the estimate: 55%); middle value at least 1.8-fold (0.26 log units) away from the limit.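

Compound 1 and compound 4 each give only a limit of the assay, and the step between them cannot be read. The compounds shown leave open what actual number either would give in this assay, and whether 3-chloro-4-fluorophenyl in place of 3-methoxyphenyl changes it at all.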